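The compounds below may be only part of what the source reports. "The series", "measured", "known", "first", "only" and "open" are said of these compounds alone.

Compound 1 `CCCCCCCCCCCCCCCC(=O)OCC(COP(=O)(O)OCCN)OC`: 49.5% in a functional assay on PC-3 cells (Homo sapiens) for cytotoxicity, read by resazurin assay, with a stated time of 48 h, tested at 25 uM; on this read-out higher numbers stand for a weaker effect at the one concentration tested and lower numbers for a stronger effect
Compound 2 `CCCCCCCCCCCCCC(=O)OCC(COP(=O)(S)OCCN)OC`: 59.8% in this assay

On these two numbers compound 2 stands highest, so its effect at the one concentration is the weaker of the pair; its nearest neighbour, compound 1, lies lower by a gap beyond the usual scatter. Compound 3 `CCCCCCCCCCCCCCCC(=O)OCC(COP(=O)(S)OCCN)OC` has not yet been measured in this assay. It differs from compound 2 by ethyl in place of hydrogen on a saturated chain carbon, ten or more bonds along the chain from a carbonyl carbon. Among the compounds with values here, no measured pair shows this same change, so its effect cannot be read off these data. The step of a number 6.8 percentage points lower from compound 2 to compound 3 (within the scatter) is expected to be small and downward, toward a somewhat stronger effect, close to the edge of the scatter. Compound 3 is therefore estimated to give 53%, within 40% to 66%.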

Compound 3, a percentage reported as activity, at one concentration (the size of the read-out at that concentration, not a potency): 79.1%
Compound 3: the middle estimate sits 26.1 percentage points below what was measured; the measured number lies above the stated range.
By their numbers in this assay, from the lowest: compound 1; then compound 2; then compound 3.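

In this assay, ethyl in place of hydrogen on a saturated chain carbon, ten or more bonds along the chain from a carbonyl carbon, weakens the effect (a number 19.3 percentage points higher from compound 2 to compound 3 (beyond the scatter)). So this far end of the chain does matter when sulfanyl sits on the phosphorus. Sulfanyl in place of hydroxy on a phosphorus also weakens the effect (a number 29.6 percentage points higher from compound 1 to compound 3 (beyond the scatter)). Nothing measured here gives a reason for either step.

Going by these compounds, whether a still longer chain at this place would weaken the effect further remains open. So does whether the same chain change behaves alike with hydroxy on the phosphorus.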